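The source may report more compounds than this note shows. Statements on the series, on what has been measured and on what is new or still open speak of the compounds shown alone.

Of the compounds shown here, three sharing one core have been measured in a physicochemical assay for solubility; on this read-out lower numbers stand for lower solubility and higher numbers for higher solubility. Compound 1 `CN1CCN(c2cc(C(F)(F)F)ccc2[C@H]2CCOc3cc(S(=O)(=O)Nc4nccs4)ccc32)CC1`, which carries 4-methylpiperazin-1-yl, gives 176000 nM. Compound 2 `O=C1OCCN1c1cc(C(F)(F)F)ccc1[C@H]1CCOc2cc(S(=O)(=O)Nc3nccs3)ccc21`, which carries 2-oxo-1,3-oxazolidin-3-yl, gives 295000 nM, and the comparison between them is a 1.7-fold higher number from compound 1 to compound 2 (0.22 log units; within the scatter). Compound 3 `O=S(=O)(Nc1nccs1)c1ccc2c(c1)OCC[C@@H]2c1ccc(C(F)(F)F)cc1-c1ccc(F)cn1`, which carries 5-fluoropyridin-2-yl, gives 7000 nM, the lowest of the three numbers.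

Compound 4 `O=S(=O)(Nc1nccs1)c1ccc2c(c1)OCC[C@@H]2c1ccc(C(F)(F)F)cc1N1CCNCC1` has not yet been measured. In it, piperazin-1-yl takes the place of 5-fluoropyridin-2-yl on an aromatic carbon, ortho to a large group and meta to a trifluoromethyl group: piperazin-1-yl in place of 5-fluoropyridin-2-yl on an aromatic carbon. Among the compounds with values here, two measured steps bear on this exchange, a 25-fold lower number from compound 1 to compound 3 (1.40 log units; beyond the scatter) and a 42-fold lower number from compound 2 to compound 3 (1.62 log units; beyond the scatter). Both are large, and both put 5-fluoropyridin-2-yl in place of another group, whereas the new change removes it. By name, the closest measured group to piperazin-1-yl is the 4-methylpiperazin-1-yl of compound 1, at 176000 nM. Within the data shown here, no measured compound carries piperazin-1-yl itself, so this comparison remains an analogy. A large rise is therefore expected, and the estimated step is a 24-fold higher number from compound 3 to compound 4 (1.39 log units; beyond the scatter). For compound 4 the estimated value is 170000 nM, with an expected range from 60000 nM to 400000 nM.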

Compound 4, solubility: 288000 nM
For compound 4 the middle estimate is 1.7-fold (0.23 log units) below the measured one; measured number inside the range.
By their numbers in this assay, from the lowest: compound 3; then compounds 1, 4 and 2 (each within the scatter of the next).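

In this assay, the step of a 41-fold higher number from compound 3 to compound 4 (1.61 log units; beyond the scatter) shows that the low number of compound 3 belongs to the 5-fluoropyridin-2-yl group and not to this position, on an aromatic carbon ortho to a large group and meta to a trifluoromethyl group, as such. The amine series adds little beyond that: the step of a 1.6-fold higher number from compound 1 to compound 4 (0.21 log units; within the scatter) shows that taking the methyl off the ring nitrogen leaves the number within the scatter, and the step of a 1.0-fold lower number from compound 2 to compound 4 (0.01 log units; within the scatter) puts piperazin-1-yl within the scatter of 2-oxo-1,3-oxazolidin-3-yl too, so compounds 1, 2 and 4 form one group of values, with compound 3 as the only one outside it. Nothing in hand accounts for the separation between compound 3 and the other three.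

The compounds shown leave open whether it is the aromatic ring or the fluorine that goes with the low number, which a plain phenyl or an unfluorinated pyridin-2-yl at this position would help to separate. They also leave open whether an open-chain group such as dimethylamino or a morpholine ring would join compounds 1, 2 and 4 or fall nearer compound 3.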